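This account rests on a few compounds, and the source may have more. Where it says the series, first, only, none or still open, it means among the compounds named here.

In a functional assay on V79 cells (Cricetulus griseus) for cytotoxicity, read by colony formation (a lower number here means a stronger inhibitor, a higher number a weaker inhibitor), compound 1 `NC1CCN(c2c(F)cc3c(=O)c(C(=O)O)cn(C4CC4)c3c2Cl)CC1` gives 18 ug/mL, compound 2 `NC1CCN(c2c(F)c(F)c3c(=O)c(C(=O)O)cn(C4CC4)c3c2F)C1` gives 100 ug/mL and compound 3 `NC1CCN(c2c(F)c(F)c3c(=O)c(C(=O)O)cn(C4CC4)c3c2C(F)(F)F)C1` gives 190 ug/mL. Compound 2 therefore sits clearly higher than compound 1 and level, within the scatter, with compound 3. Compound 4 `NC1CCN(c2c(F)c(O)c3c(=O)c(C(=O)O)cn(C4CC4)c3c2F)C1` is still unmeasured and carries hydroxy in place of fluoro on an aromatic carbon. Among the compounds with values here, the only measured step that also replaces a fluoro on an aromatic carbon is a 1.9-fold higher number from compound 2 to compound 3 (0.28 log units; within the scatter), where trifluoromethyl enters instead. A different group enters in compound 4, so this is thin evidence, but it gives no reason to expect a step beyond the scatter in this assay. The expected change is no change at the digits printed from compound 2 to compound 4 (within the scatter). For compound 4 the estimated value is 100 ug/mL, with an expected range of 40 ug/mL to 230 ug/mL.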

Compound 4, half-maximal inhibitory concentration: 43 ug/mL
Compound 4: middle estimate off by 2.3-fold (0.37 log units), on the high side, within the range that was stated.
By their numbers in this assay, from the lowest: compound 1; then compound 4; then compounds 2 and 3 (each within the scatter of the next).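

At this carbon, ortho to a fused ring and to a fluoro group, this assay responds to the swap of fluoro for hydroxy: the step is a 2.3-fold lower number from compound 2 to compound 4 (0.37 log units; beyond the scatter). The only earlier replacement, at a different fluoro of compound 2, stayed within the scatter at a 1.9-fold higher number from compound 2 to compound 3 (0.28 log units; within the scatter), so this is the first step shown that moves the number measurably, here towards stronger inhibition. No evidence is available to explain this shift. The compounds shown leave open whether an amine or a methoxy group on this carbon would lower the number as well. They also leave open whether hydroxy has the same effect at other positions on the core.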